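Swapping ethoxy for isopropyl on an arylpiperazine antagonist

This account rests on a few compounds, and the source may have more. Where it says the series, first, only, none or still open, it means among the compounds named here.

Measured so far:
compound 1, `COc1ccccc1N1CCN(CCCNc2nc(C)cc(C)c2C(N)=O)CC1`, gives 39.8 nM;
compound 2, `COc1ccccc1N1CCN(CCCNc2ccccc2C(=O)c2ccccc2)CC1`, gives 10 nM;
compound 3, `CCOc1ccccc1N1CCN(CCCNc2ncccc2C(=O)N(C)C)CC1`, gives 7.94 nM.

These three were tested in a functional assay on aorta for antagonist activity at Alpha-1D adrenergic receptor (Rattus norvegicus); on this read-out higher numbers stand for weaker binding and lower numbers for tighter binding. Compound 3 shows the lowest number of the three. Its nearest neighbour is compound 2, whose value sits within the usual scatter of this assay, so the two cannot be ranked against each other. Compound 1 lies clearly further away, beyond the scatter, with the highest number in the set.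

Compound 4, `CC(C)c1ccccc1N1CCN(CCCNc2ncccc2C(=O)N(C)C)CC1`, has not yet been measured. It differs from compound 3 in a single place: isopropyl in place of ethoxy on an aromatic carbon. The amide, the pyridine part and the piperazine linker are unchanged; only the small group on the phenyl ring is exchanged for one without an oxygen.

Among the measured compounds shown here, no measured pair in this set shares exactly this change, so the expected step rests on the structural change alone. A small shift toward a weaker number is expected for compound 4, though it may not exceed the scatter, with a 1.9-fold higher number from compound 3 to compound 4 (0.28 log units; within the scatter) as the estimated step. Compound 4 is therefore expected to give about 15 nM in this assay, most likely between 5 nM and 50 nM.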

Compound 4, dissociation constant: 63.1 nM
Compound 4: the middle estimate sits 4.2-fold (0.62 log units) below what was measured, outside the stated range (above it).
By their numbers in this assay, from the lowest: compounds 3 and 2 (each within the scatter of the next); then compounds 1 and 4 (each within the scatter of the next).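

In this assay, isopropyl in place of ethoxy on this aromatic carbon, ortho to a large group, gives a 7.9-fold higher number from compound 3 to compound 4 (0.90 log units; beyond the scatter) and so moves the read-out beyond the scatter. The two groups match in heavy atoms, with 3 each and no ring, yet the position does not treat them alike; by the count, they differ in that ethoxy holds an oxygen and a hydrogen-bond acceptor while isopropyl holds neither. Nothing in the data says why the number rises.

Open, going by these compounds, is whether the oxygen or the branched carbon shape lies behind the step, a question that a group such as propyl or cyclopropyl at the same place could help to answer. On these data alone, this change appears in a single pair, so its size on any other core remains unknown.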